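Swapping bromine for chlorine on a sulfonamide ring

This account rests on a few compounds, and the source may have more. Where it says the series, first, only, none or still open, it means among the compounds named here.

Three cyclohexanone sulfonamides share one core and differ only in what sits on the aniline ring. In a functional assay on BGC-823 cells (Homo sapiens) for antiproliferative activity, read by sulforhodamine B assay, tested at 100 ug/mL (on this read-out lower numbers stand for less inhibition and higher numbers for more inhibition at the one concentration tested (going by the name of the read-out)), compound 1 `O=C1CCCCC1S(=O)(=O)Nc1ccccc1Br` gives 29.6%, the lowest of the three numbers. Compound 2 `O=C1CCCCC1S(=O)(=O)Nc1ccc(Cl)cc1C(F)(F)F` gives 36.4%, which lies within the scatter of compound 1, so the two cannot be told apart. Compound 3 `O=C1CCCCC1S(=O)(=O)Nc1cc(C(F)(F)F)ccc1C(F)(F)F` gives 57.7%, a number that stands beyond the scatter above compound 1 and is the only clear separation among the three.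

Compound 4 `O=C1CCCCC1S(=O)(=O)Nc1ccccc1Cl` has not been measured. It differs from compound 1 in one place: chloro in place of bromo on an aromatic carbon. Both halogens are single atoms without ring, donor or acceptor, and they occupy the same aromatic carbon.

For the measured compounds named here, nothing among the measured compounds shows what this exchange does, so no direction can be drawn from data. The step from compound 1 to compound 4 is expected to be a number 1.6 percentage points lower from compound 1 to compound 4 (within the scatter), within the scatter. Compound 4 is therefore estimated at 28%, with a range from 15% to 42%.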

Compound 4, a percentage reported as inhibition, at one concentration (the size of the read-out at that concentration, not a potency): 29.2%
Estimate against measurement, compound 4: 1.2 percentage points below; the range from low to high includes it.
By their numbers in this assay, from the lowest: compounds 4, 1 and 2 (each within the scatter of the next); then compound 3.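

For the compounds shown here, this pair is the first in the set that differs in only one place, so the effect of a single change can finally be read on its own. In this assay, chloro in place of bromo on an aromatic carbon, ortho to a large group, gives a number 0.4 percentage points lower from compound 1 to compound 4 (within the scatter), so this assay cannot tell the two halogens apart at this position. No measurement on hand offers an explanation for this result.

The compounds shown leave open whether an amine or a carboxylic acid on this same carbon would give a number beyond the scatter of compound 1. They also leave open whether the same exchange of halogens on another carbon of the ring would give as small a step.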